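The compounds below may be only part of what the source reports. "The series", "measured", "known", "first", "only" and "open" are said of these compounds alone.

Measured so far:
- compound 1 `Cc1cc(-c2cnc(NCc3c(F)ccc4c3CCO4)c3cn[nH]c(=O)c23)n(C)n1`: 3
- compound 2 `Cc1ncccc1-c1cnc(NCc2c(F)ccc3c2CCO3)n2c(=O)[nH]nc12`: 3

In a physicochemical assay for lipophilicity, using the shake flask method, in phosphate buffer, measured as octanol-water partition, with a stated time of 30 min, at pH 7.4 (a lower number here means a more polar compound, a higher number a more lipophilic compound), compound 1 gives 3. Compound 2 in this assay gives 3, so the two values are level at the digits shown and lie within the scatter of each other; no step between them is counted.

Compound 3 `CC(=O)N1CCC(c2cnc(NCc3c(F)ccc4c3CCO4)c3cn[nH]c(=O)c23)CC1` has not yet been run in this assay. Against compound 1 the change is 1-acetylpiperidin-4-yl in place of 1,3-dimethyl-1H-pyrazol-5-yl on an aromatic carbon.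

Within the data shown here, no measured step of this kind exists. A drop beyond the scatter is expected, estimated as a number 1.00 log units lower from compound 1 to compound 3 (beyond the scatter). For compound 3 the expected value in this assay is 2, with a range from 1.4 to 2.6.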

Compound 3, distribution coefficient: 2.9
Estimate against measurement, compound 3: 0.90 log units below; measured number above the stated range.
By their numbers in this assay, from the lowest: compounds 3, 1 and 2 (each within the scatter of the next).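

In this assay, 1-acetylpiperidin-4-yl in place of 1,3-dimethyl-1H-pyrazol-5-yl on this aromatic carbon gives a number 0.10 log units lower from compound 1 to compound 3 (within the scatter) on the shared core. This position therefore takes a six-membered non-aromatic ring with an acetyl group instead of a five-membered aromatic ring, with no step beyond the scatter. Nothing measured here gives a reason for this result. Still open, as far as these compounds go, is whether an amine, such as the piperidine without its acetyl, or a carboxylic acid at this position would give a step beyond the scatter. Also open, from the compounds shown here alone, is whether 1-acetylpiperidin-4-yl behaves alike on the core of compound 2.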